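Swapping the ethyl of compound 2 for a hydroxy group

The source may hold more compounds than are shown below. What is called first, only, known or untested is meant among the compounds shown, and "the series" means these compounds.

The shared core carries a small group on the five-membered ring, and that group is where the two measured compounds differ. Compound 1 `Cc1nc2c(N)ncnc2n1[C@@H]1O[C@H](CN(C)CCCCON)[C@@H](O)[C@H]1O` has a methyl there; in an assay on isolated protein for inhibition of S-adenosylmethionine decarboxylase proenzyme (Homo sapiens) (a lower number here means a stronger inhibitor, a higher number a weaker inhibitor), compound 1 gives 5 nM. Compound 2 `CCc1nc2c(N)ncnc2n1[C@@H]1O[C@H](CN(C)CCCCON)[C@@H](O)[C@H]1O` carries an ethyl instead, and in this assay compound 2 gives 15 nM, the higher of the two numbers. Among the measured compounds shown here, the only measured step, a 3.0-fold higher number from compound 1 to compound 2 (0.48 log units; beyond the scatter), shows that lengthening this group weakens inhibition modestly. Compound 3 `CN(CCCCON)C[C@H]1O[C@@H](n2c(O)nc3c(N)ncnc32)[C@H](O)[C@@H]1O` changes the same position in a different way: hydroxy in place of ethyl on an aromatic carbon. For the measured compounds named here, no measured step covers a hydroxy at this spot, so the one step from compound 1 to compound 2 is the only guide, and it says the position tolerates change with a modest penalty. Compound 3 is therefore expected to land near compound 2, with a 2.0-fold higher number from compound 2 to compound 3 (0.30 log units; within the scatter) as the estimated step, giving an estimate of 30 nM with a range from 8 nM to 120 nM.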

Compound 3, half-maximal inhibitory concentration: 11 nM
The estimate for compound 3 lay 2.7-fold (0.44 log units) above the measured number; low and high end bracket the measured number.
By their numbers in this assay, from the lowest: compound 1; then compounds 3 and 2 (each within the scatter of the next).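

In this assay the change from ethyl to hydroxy gives a 1.4-fold lower number from compound 2 to compound 3 (0.13 log units; within the scatter) and so stays within the usual scatter: compound 2 and compound 3 cannot be told apart, although a group with no hydrogen-bond donor or acceptor has given way to one with both. Measured against the methyl group, the hydroxy gives a 2.2-fold higher number from compound 1 to compound 3 (0.34 log units; beyond the scatter) and this lies beyond the scatter, so compound 1 remains the strongest inhibitor of the three, and the position accepts two very different replacements for methyl at only a modest cost. Nothing available explains why the numbers fall this way.

On these data alone, whether an amine, a methoxy group or a longer chain here would stay this close remains open. So does the effect of a plain hydrogen at this position.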